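Extending the amine nitrogen of a coumarin hydrazide

This account rests on a few compounds, and the source may have more. Where it says the series, first, only, none or still open, it means among the compounds named here.

Measured compounds:
compound 1, `O=C(O)c1cc2cc(I)cc(I)c2oc1=O`, 17800 nM
compound 2, `NNC(=O)c1cc2ccccc2oc1=O`, 3.22 nM

Of the compounds shown here, two have been measured in an in vitro assay on BTI-TN-5B1-4 cells for inhibition of Amine oxidase [flavin-containing] B (Homo sapiens), read by fluorescence, with a stated time of 15 min; a lower number here means a stronger inhibitor, a higher number a weaker inhibitor. Compound 1 gives 17800 nM in this assay. Compound 2 gives 3.22 nM, the lowest of the two numbers, and the gap that separates it from compound 1 lies far beyond the scatter of the assay. Going by the values given here, the two structures differ in more than one place, so no single step between them can be read.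

Compound 3, `O=C(NNc1ccc(Cl)cc1)c1cc2ccccc2oc1=O`, has not yet been measured. It differs from compound 2 in one place: 4-chlorophenyl in place of hydrogen on an amine nitrogen. Nothing in the measured pair speaks to such a change, since the terminal nitrogen of compound 2 carries only hydrogen. The expectation for compound 3 therefore rests on compound 2 alone. A modest move toward a higher number is expected, estimated as a 6.2-fold higher number from compound 2 to compound 3 (0.79 log units; beyond the scatter), which would be a step beyond the scatter but well short of the gap to compound 1. Compound 3 is expected to give about 20 nM in this assay, within a range from 2 nM to 200 nM.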

Compound 3, half-maximal inhibitory concentration: 1190 nM
Estimate against measurement, compound 3: 60-fold (1.77 log units) below; measured number above the stated range.
By their numbers in this assay, from the lowest: compound 2; then compound 3; then compound 1.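

In this assay, going by these compounds alone, 4-chlorophenyl in place of hydrogen on the amine nitrogen brings a 370-fold higher number from compound 2 to compound 3 (2.57 log units; beyond the scatter), a large step and the first reading of any kind at this position. It shows that the number in this assay depends strongly on what this nitrogen carries: with only hydrogen there, compound 2 stands at 3.22 nM, whereas with the 4-chlorophenyl group compound 3 stands at 1190 nM, so this single change costs much of the inhibition while leaving a measurable value. Within the data shown here, compound 1 differs from both compound 2 and compound 3 in more than one place, so no step to it can be read, and this one step remains the only reading of the position.

With only hydrogen and 4-chlorophenyl on this nitrogen, the compounds shown leave open whether a methyl group, an unsubstituted phenyl ring or a benzyl group would give a number nearer that of compound 2 or that of compound 3, and so whether the chlorine or the ring itself accounts for the step. Nothing among the data shown gives a reason for this rise in the number.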